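A few compounds are considered here, and "the series" means these few. Any claim that something is new, unique, unknown or untested is made for them only; others in the source may bear on it.

Compound 2 `CC(O)Cn1nnc(-c2ccccc2-c2ccc(CN3C(=O)[C@H](NC(=O)CC(C)(C)N)CCc4ccccc43)cc2)n1` is one of a pair built on a shared core, the other being compound 1 `CC(O)Cn1nnnc1-c1ccccc1-c1ccc(CN2C(=O)[C@H](NC(=O)CC(C)(C)N)CCc3ccccc32)cc1`. In a functional assay (Pituitary gland cell) with Rattus norvegicus as the target (a lower number here means that less compound is needed, a higher number that more compound is needed for the effect), compound 2 gives 0.05 uM, and compound 1 gives 0.05 uM, so the two stand level. Among the compounds with values here, the one measured step, no change at the digits printed from compound 1 to compound 2 (within the scatter), moves only the point at which the hydroxypropyl chain is attached to the tetrazole ring and leaves the chain itself untouched. Compound 3 `CC(C)(N)CC(=O)N[C@@H]1CCc2ccccc2N(Cc2ccc(-c3ccccc3-c3nnn(CC(=O)O)n3)cc2)C1=O`, not yet measured, changes that chain: carboxy in place of 1-hydroxyethyl on a saturated chain carbon bound to an aromatic nitrogen. Within the data shown here, no measured step touches this end of the molecule, so the expectation rests only on the fact that the chain tolerated being moved without any change in this assay. A modest loss is expected, with compound 3 estimated at 0.1 uM, between 0.02 uM and 0.5 uM, which means an expected step of a 2.0-fold higher number from compound 2 to compound 3 (0.30 log units; within the scatter).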

Compound 3, concentration for half-maximal effect: 0.2 uM
Beside the measured number, compound 3's estimate is 2.0-fold (0.30 log units) below it; low and high end bracket the measured number.
By their numbers in this assay, from the lowest: compounds 1 and 2 (each within the scatter of the next); then compound 3.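

In this assay, within the data shown here, the group at the end of the chain matters more than the point where the chain is attached: carboxy in place of 1-hydroxyethyl gives a 4.0-fold higher number from compound 2 to compound 3 (0.60 log units; beyond the scatter) and this modest step is the first here to lie beyond the scatter. Measured against the other hydroxypropyl compound, the change to 2-(carboxymethyl)-2H-tetrazol-5-yl gives the same size of step, a 4.0-fold higher number from compound 1 to compound 3 (0.60 log units; beyond the scatter) and so the loss appears whichever of the two serves as the reference. No measurement shown here explains this loss.

On these data alone, whether a primary amide or a methyl ester in place of the carboxy group would return the number to that of compound 2 remains open. So does the effect of a longer chain carrying the carboxy group, such as carboxyethyl.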